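A Second Pyridin-2-yl Amide on the Shared Core

This account rests on a few compounds, and the source may have more. Where it says the series, first, only, none or still open, it means among the compounds named here.

Compound 1, `COc1ccc(C(=O)N[C@H]2CCC[C@H](NC(=O)c3cccc(Cl)c3)C2)cc1`, in a functional assay on HEK293 cells for antagonist activity at metabotropic glutamate receptor 5 (Homo sapiens), read by FLIPR and calcium flux; a higher number here means a weaker inhibitor, a lower number a stronger inhibitor: 266 nM
Compound 2, `O=C(NC1CCCC(NC(=O)c2ccccn2)C1)c1cccc(Cl)c1`: 314 nM
Compound 3, `O=C(N[C@H]1CCC[C@H](NC(=O)c2ccccn2)C1)c1cccc(Cl)c1`: > 10000 nM, a limit

Compound 1 and compound 2 give numbers in this assay that lie within the scatter of each other. Compound 3 gives only a limit in this assay, > 10000 nM, and so stands at the weak end of what is shown. Two steps lead to it. From compound 1, an at least 37-fold higher number from compound 1 to compound 3 (1.57 log units; beyond the scatter). From compound 2, an at least 31-fold higher number from compound 2 to compound 3 (1.50 log units; beyond the scatter); the two readings differ at the fact that one of compounds 2 and 3 is drawn with a defined configuration and the other without, at the place where they differ.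

Compound 4, `O=C(N[C@H]1CCC[C@H](NC(=O)c2ccccn2)C1)c1ccccn1`, has not yet been measured. It differs from compound 3 by pyridin-2-yl in place of 3-chlorophenyl on a carbonyl carbon. The step that bears on it most is an at least 37-fold higher number from compound 1 to compound 3 (1.57 log units; beyond the scatter), the same kind of exchange on a carbonyl carbon, and it was large and toward a higher number. Compound 3 already sits at the limit of > 10000 nM in this assay, at which 1 of the 3 values shown sits. For compound 4 the expected step is therefore a step that the limit leaves unreadable from compound 3 to compound 4, most likely hidden behind the limit. Compound 4 is expected to give about 30000 nM in this assay, with a range from 8000 nM to 150000 nM.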

Compound 4, half-maximal inhibitory concentration: 1150 nM
Compound 4: the middle estimate sits 26-fold (1.42 log units) above what was measured, outside the stated range (below it).
By their numbers in this assay, from the lowest: compounds 1 and 2 (each within the scatter of the next); then compound 4. At a limit, above all of these: compound 3.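

Compound 3 gives only a limit, > 10000 nM, in this assay. Putting pyridin-2-yl in place of 3-chlorophenyl on a carbonyl carbon gives an at least 8.6-fold lower number from compound 3 to compound 4 (0.93 log units; beyond the scatter), whereas pyridin-2-yl in place of 4-methoxyphenyl on a carbonyl carbon gave an at least 37-fold higher number from compound 1 to compound 3 (1.57 log units; beyond the scatter), so the same entering group moves the number in opposite directions in these two steps. Compound 4 carries no chlorine and, unlike compound 3, gives a measured number, so a 3-chlorophenyl group is not required for a readable value on this core.

From the compounds shown here alone, the true size of the new step stays unreadable because compound 3 sits at a limit: the limit of > 10000 nM in this assay, at which 1 of the 4 values shown sits. Also open is how a pyrimidin-2-yl group or a carboxylic acid on this carbonyl carbon would read in this assay.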